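This account rests on a few compounds, and the source may have more. Where it says the series, first, only, none or still open, it means among the compounds named here.

Compound 1 `O=C(NCCCNc1cc(-c2cn(-c3ccccc3)nc2-c2cccc(O)c2)ccn1)Nc1ccc(F)cc1`: 2540 nM
Compound 2 `O=C(NCCCNc1cc(-c2cn(-c3ccccc3)nc2-c2cccc(O)c2)ccn1)Nc1cccc(C(F)(F)F)c1`: 3480 nM

Both values come from a functional assay on SK-MEL-28 cells (Homo sapiens) for antiproliferative activity, read by sulforhodamine B assay, with a stated time of 48 h; on this read-out lower numbers stand for stronger inhibition and higher numbers for weaker inhibition. Among the compounds with values here, compound 1 has only one measured neighbour, and the two compounds cannot be told apart: the step is a 1.4-fold higher number from compound 1 to compound 2 (0.14 log units; within the scatter). So compound 1 stands level with compound 2, in the low micromolar part of the scale.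

Compound 3 `COc1cccc(-c2nn(-c3ccccc3)cc2-c2ccnc(NCCCNC(=O)Nc3ccc(F)cc3)c2)c1` keeps the core and the 4-fluorophenyl group of compound 1 and has not yet been measured. The change is methyl in place of hydrogen on an oxygen on an aromatic ring, which turns the 3-hydroxyphenyl group into a 3-methoxyphenyl group.

Within the data shown here, the only measured step, a 1.4-fold higher number from compound 1 to compound 2 (0.14 log units; within the scatter), concerns a different place, the group on an amide-type nitrogen. It shows that this one swap left the number within the scatter, but it says nothing direct about the oxygen. Among the measured compounds shown here, no measured pair tests hydroxy against methoxy, so the data give no direction, and no step beyond the scatter is expected, though with wide uncertainty.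

The estimated step is a 1.2-fold higher number from compound 1 to compound 3 (0.07 log units; within the scatter). For compound 3 the expected value is 3000 nM, with an estimated range from 1000 nM to 9000 nM.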

Compound 3, half-maximal inhibitory concentration: 6570 nM
The estimate for compound 3 lay 2.2-fold (0.34 log units) below the measured number, and the stated range covers the measured number.
By their numbers in this assay, from the lowest: compounds 1, 2 and 3 (each within the scatter of the next, the first and the last beyond it).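

Within the data shown here, this is the first measured test of the oxygen on the 3-hydroxyphenyl group, and in this assay the change registers: methyl in place of hydrogen there gives a step beyond the scatter (a 2.6-fold higher number from compound 1 to compound 3 (0.41 log units; beyond the scatter)), though a modest one. The earlier swap on the amide-type nitrogen stayed within the scatter (a 1.4-fold higher number from compound 1 to compound 2 (0.14 log units; within the scatter)), so of the two places changed so far, only the oxygen has produced a readable difference, in the direction of weaker inhibition. Nothing available explains why this step occurs, so it stands as an observation only.

The compounds shown leave open whether the hydrogen on this oxygen is what counts, or whether any replacement of the hydroxy group, such as an amine or a longer ethoxy chain, would move the number in the same way. They also leave open whether the step from hydroxy to methoxy would look the same with the 3-(trifluoromethyl)phenyl group of compound 2 in place of the 4-fluorophenyl group.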